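The compounds below may be only part of what the source reports. "The series", "measured", "known", "first", "only" and "open" are said of these compounds alone.

Compound 1 `CCc1ccc(NC(=O)c2csc(Cc3c(Cl)cccc3Cl)n2)cc1` is the starting point. Going by the values given here, in an assay on CHO cells, read by calcium flux (a lower number here means a stronger inhibitor, a higher number a weaker inhibitor), compound 1 gives 810 nM, the only number measured here. For compound 2 `CN(C)c1ccc(NC(=O)c2csc(Cc3c(Cl)cccc3Cl)n2)cc1` the assay reports only a limit, > 4000 nM. That amounts to an at least 4.9-fold higher number from compound 1 to compound 2 (0.69 log units; beyond the scatter). Compound 3 `O=C(Nc1ccc(C(F)(F)C(F)(F)F)cc1)c1csc(Cc2c(Cl)cccc2Cl)n1` carries a different change from compound 1: 1,1,2,2,2-pentafluoroethyl in place of ethyl on an aromatic carbon. Among the compounds with values here, no measured step shares this change, and the one step known replaced ethyl with dimethylamino, so it is only a loose guide. The expected change in this assay is a 1.5-fold higher number from compound 1 to compound 3 (0.17 log units; within the scatter), a small one. The estimate for compound 3 is 1200 nM, with a range from 350 nM to 4000 nM.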

Compound 3, half-maximal inhibitory concentration: 290 nM
Compound 3: middle estimate off by 4.1-fold (0.62 log units), on the high side, and the stated range ends above it.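

Replacing ethyl with 1,1,2,2,2-pentafluoroethyl on this aromatic carbon gives a 2.8-fold lower number from compound 1 to compound 3 (0.45 log units; beyond the scatter), so in this assay this position accepts a group with more heavy atoms and the inhibitor becomes stronger. Putting the same group in place of dimethylamino gives an at least 13-fold lower number from compound 2 to compound 3 (1.13 log units; beyond the scatter). The size of that second step is open-ended, since the result for compound 2 is a limit and not a number: the limit of > 4000 nM in this assay, at which 1 of the 3 values shown sits.

Going by these compounds, whether trifluoromethyl or a longer fluorinated chain would do as well remains open. So does whether a primary amine at this position would behave like dimethylamino.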